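The source may report more compounds than this note shows. Statements on the series, on what has been measured and on what is new or still open speak of the compounds shown alone.

Measured in a functional assay on A549 cells (Homo sapiens) for inhibition, read by MTT assay, with a stated time of 72 h; a lower number here means a stronger inhibitor, a higher number a weaker inhibitor:
- compound 1 `CC1=NN(c2ccccc2)C(=O)[C@@]12C(=O)C=CC[C@H]2c1ccc(C)cc1`: 6090 nM
- compound 2 `CC1=NN(c2ccccc2)C(=O)[C@@]12C(=O)C=CC[C@@H]2c1ccc(C)cc1`: 6570 nM
- compound 3 `CC1=NN(c2ccccc2)C(=O)[C@]12C(=O)C=CC[C@@H]2c1ccc(C)cc1`: 8600 nM

Compound 3, at 8600 nM, stands level with the other two stereoisomers. The a 1.3-fold higher number from compound 2 to compound 3 (0.12 log units; within the scatter) and a 1.4-fold higher number from compound 1 to compound 3 (0.15 log units; within the scatter) both stay within the scatter, as does a 1.1-fold higher number from compound 1 to compound 2 (0.03 log units; within the scatter). Configuration alone does not separate these three in this assay.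

The next compound is compound 4 `CC1=NN(c2ccccc2)C(=O)[C@]12C(=O)C=CC[C@@H]2c1cccc(C)c1`. The change is 3-methylphenyl in place of 4-methylphenyl on a saturated ring carbon, with 3-methylphenyl in place of 4-methylphenyl on a saturated ring carbon. Among the compounds with values here, no measured step moves the methyl group, since all three alter configuration only, so they bear on this change only indirectly. Within the data shown here, they show a flat series and offer no precedent for a shift in either direction. With compound 3 at 8600 nM as the anchor, no change beyond the scatter is expected. The expected step is a 1.1-fold lower number from compound 3 to compound 4 (0.06 log units; within the scatter). For compound 4 the estimated value is 7500 nM, with an expected range of 3500 nM to 16000 nM.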

Compound 4, half-maximal inhibitory concentration: 4770 nM
Compound 4: the middle estimate sits 1.6-fold (0.20 log units) above what was measured, and the stated range covers the measured number.
By their numbers in this assay, from the lowest: compounds 4, 1, 2 and 3 (each within the scatter of the next).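

In this assay, 3-methylphenyl in place of 4-methylphenyl on the saturated ring carbon gives a 1.8-fold lower number from compound 3 to compound 4 (0.26 log units; within the scatter). Within the data shown here, this is the first step that alters the group itself rather than the configuration as drawn, and like the configuration steps it stays within the scatter, so the assay does not separate these two methylphenyl placements at this position. Nothing on hand accounts for the size of this step.

The compounds shown leave open whether the position responds to anything beyond a relocated methyl, such as an amine, a carboxylic acid or a longer chain like propyl on the phenyl ring. They also leave open whether 3-methylphenyl stays as insensitive to configuration as 4-methylphenyl does, since compound 4 stands alone in a single configuration.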